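A Chloro Added to Compound 2

The source may hold more compounds than are shown below. What is called first, only, known or untested is meant among the compounds shown, and "the series" means these compounds.

Going by the values given here, compound 2 `CC(C)(C)c1ccc(S(=O)(=O)Nc2ccc(Cl)cc2-c2nccnc2NCCO)cc1` gives 34 nM in a functional assay on isolated protein for antagonist activity at C-C chemokine receptor type 9 (Homo sapiens), read by calcium flux, with a stated time of 10 min (a higher number here means a weaker inhibitor, a lower number a stronger inhibitor), the lowest of the two numbers measured so far; compound 1 `CC(C)(C)c1ccc(S(=O)(=O)Nc2ccc(Cl)cc2-c2c(O)ccc[n+]2[O-])cc1` gives 491 nM in this assay. Among the compounds with values here, the only measured step, a 14-fold lower number from compound 1 to compound 2 (1.16 log units; beyond the scatter), swapped one whole ring for another and therefore says nothing direct about adding a single atom. Compound 3 `CC(C)(C)c1ccc(S(=O)(=O)Nc2ccc(Cl)cc2-c2nc(Cl)cnc2NCCO)cc1` differs from compound 2 by chloro in place of hydrogen on an aromatic carbon. Within the data shown here, with no measured step bearing on this change, compound 3 is expected to move little, a step of a 1.4-fold lower number from compound 2 to compound 3 (0.13 log units; within the scatter) that is not beyond the scatter. Compound 3 is estimated at 25 nM, within a range of 8 nM to 80 nM.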

Compound 3, half-maximal inhibitory concentration: 715 nM
Compound 3: the middle estimate sits 29-fold (1.46 log units) below what was measured; the measured number lies above the stated range.
By their numbers in this assay, from the lowest: compound 2; then compounds 1 and 3 (each within the scatter of the next).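

Chloro in place of hydrogen, on the aromatic carbon para to the (2-hydroxyethyl)amino group, brings a 21-fold higher number from compound 2 to compound 3 (1.32 log units; beyond the scatter) in this assay and so marks this carbon as sensitive. The earlier ring swap could not show this, since there a whole ring changed, whereas here one added heavy atom is enough for a large step. No measurement shown here explains the step. From the compounds shown here alone, whether fluoro, methyl or an amine on this same carbon would give a step of similar size stays open. The compounds shown therefore cannot say whether the loss belongs to chloro itself or to any group placed here.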